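Spiro amides at the cholesterol transporter: an amine swap

The source may hold more compounds than are shown below. What is called first, only, known or untested is meant among the compounds shown, and "the series" means these compounds.

Measured compounds:
compound 1 `CC(C)(C)OC(=O)NCCCCNC(=O)CN1CN(c2ccccc2)C2(CCN(C(=O)c3ccc(C(C)(C)C)cc3)CC2)C1=O` — in an assay on HEK293 cells for displacement of a labelled ligand from NPC1-like intracellular cholesterol transporter 1 (Homo sapiens) (on this read-out higher numbers stand for weaker inhibition and lower numbers for stronger inhibition), compound 1 has "not determined" (no result reported)
compound 2 `CC(C)(C)c1ccc(C(=O)N2CCC3(CC2)C(=O)N(CC(=O)N2CCN(S(C)(=O)=O)CC2)CN3c2ccccc2)cc1` — 19000 nM

Compound 2 carries the only number shown: in this assay compound 2 gives 19000 nM. Within the data shown here, compound 1 shares the core but has no reported result, so no step between measured compounds exists to lean on. Compound 3 `CC(C)(C)c1ccc(C(=O)N2CCC3(CC2)C(=O)N(CC(=O)NCCCN)CN3c2ccccc2)cc1` is the new entry, and it differs from compound 2 by (3-aminopropyl)amino in place of 4-(methylsulfonyl)piperazin-1-yl on a carbonyl carbon — that is, (3-aminopropyl)amino in place of 4-(methylsulfonyl)piperazin-1-yl on a carbonyl carbon. With nothing measured on either side of this change, the expected step is none beyond the usual scatter, with the direction open. Compound 3 is therefore estimated at 20000 nM, within 5000 nM to 80000 nM. The expected step of a 1.1-fold higher number from compound 2 to compound 3 (0.02 log units; within the scatter) is small, and the chance that this assay reports only a limit for compound 3 is real.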

Compound 3, half-maximal inhibitory concentration: 4200 nM
Compound 3: middle estimate off by 4.8-fold (0.68 log units), on the high side; measured number below the stated range.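

In this assay this position on a carbonyl carbon proves sensitive to the group it carries: (3-aminopropyl)amino in place of 4-(methylsulfonyl)piperazin-1-yl brings a 4.5-fold lower number from compound 2 to compound 3 (0.66 log units; beyond the scatter) and gives the series its first readable step. The change is not a single feature, since the entering group is smaller, has no ring, and has hydrogen-bond donors where the leaving group has none, and this one pair cannot separate these differences. Nothing measured here accounts for the stronger inhibition.

On these data alone, it remains open whether the terminal amine or the open chain matters more, which a hydroxyl at the chain end, a shorter or longer chain, or a plain piperazine could test. The compounds shown also leave open whether the step would hold on a different core.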